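Swapping the aryl group on a thiourea-linked benzamide

The source may hold more compounds than are shown below. What is called first, only, known or untested is meant among the compounds shown, and "the series" means these compounds.

Of the compounds shown here, three with a shared chlorophenoxy-pentyl chain have been tested in an ADME assay on Huh-7 cells (Homo sapiens) for cytotoxicity; on this read-out lower numbers stand for higher toxicity in this test and higher numbers for lower toxicity in this test. Compound 1 `NC(=S)n1ccc2c(OCCCCCOc3ccc(Cl)cc3)cccc21` gives 24700 nM. Compound 2 `O=C(NC(=S)n1ccc2c(OCCCCCOc3ccc(Cl)cc3)cccc21)c1ccccc1`, which carries a benzoyl in place of hydrogen on an amide-type nitrogen, gives 29500 nM; the step of a 1.2-fold higher number from compound 1 to compound 2 (0.08 log units; within the scatter) is within the scatter. Compound 3 `O=C(NC(=S)N1CCc2c(OCCCCCOc3ccc(Cl)cc3)cccc21)c1cccc([N+](=O)[O-])c1`, built on a slightly different core, gives 12100 nM, the lowest of the three numbers, beyond the scatter from both compound 1 and compound 2.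

Compound 4 `COc1ccc(C(=O)NC(=S)N2CCc3c(OCCCCCOc4ccc(Cl)cc4)cccc32)cc1` differs from compound 3 by 4-methoxyphenyl in place of 3-nitrophenyl on a carbonyl carbon. Among the compounds with values here, no measured pair changes the group on that carbonyl carbon; the only step at hand, from compound 1 to compound 2, concerns adding the benzoyl itself and stayed within the scatter, so it bears on this change only loosely. On this thin basis the step of a 1.5-fold higher number from compound 3 to compound 4 (0.17 log units; within the scatter) is expected to stay small, if anything toward a higher number, since compound 2 with its plain benzoyl gave 29500 nM. Compound 4 is therefore estimated at 18000 nM, with a plausible range from 9000 nM to 36000 nM.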

Compound 4, half-maximal cytotoxic concentration: 34400 nM
Compound 4: middle estimate off by 1.9-fold (0.28 log units), on the low side; the measured number falls inside the stated range.
By their numbers in this assay, from the lowest: compound 3; then compounds 1, 2 and 4 (each within the scatter of the next).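

Within the data shown here, this is the first measured change of the group on the carbonyl carbon, and in this assay it moves the number beyond the scatter: a 2.8-fold higher number from compound 3 to compound 4 (0.45 log units; beyond the scatter). Among these compounds, the only earlier step, a 1.2-fold higher number from compound 1 to compound 2 (0.08 log units; within the scatter), added the benzoyl itself and stayed within the scatter, so that pair gave no sign that the aryl group on this carbonyl could matter; the new pair shows that, at least on the core of compound 3, replacing 3-nitrophenyl with 4-methoxyphenyl gives a modest shift toward lower toxicity in this test. Nothing available here accounts for why this swap shifts the number, so the step stands as an observation only.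

The swap changes both the group on the ring and its printed ring position at once, so this single pair cannot separate the two; a 3-methoxyphenyl or a 4-nitrophenyl on the same carbonyl carbon would pull them apart. Also open, on these data alone, is whether the shift extends to other aryl groups at this position, such as a 4-aminophenyl, a 4-carboxyphenyl or a pyridyl ring.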